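Methoxy in place of fluoro on the side chain

This account rests on a few compounds, and the source may have more. Where it says the series, first, only, none or still open, it means among the compounds named here.

Compound 1, `COc1cc(C(c2ccc(O)c(OC)c2)[C@@H](C)[C@H](C)CO)ccc1O`: > 100000 nM
Compound 2, `CCCCC[C@H](C(C)C)C(c1ccc(O)c(OC)c1)c1ccc(O)c(OC)c1`: 9600 nM
Compound 3, `COc1cc(C(c2ccc(O)c(OC)c2)[C@H](C)[C@@H](C)CF)ccc1O`: 45000 nM

Three compounds on one shared core were tested in a functional assay on HL-60 cells (Homo sapiens) for cytotoxicity, read by WST assay, with a stated time of 48 h; on this read-out lower numbers stand for stronger inhibition and higher numbers for weaker inhibition. Compound 1 reaches only a limit of this assay, > 100000 nM (the limit of > 100000 nM in this assay, at which 1 of the 3 values shown sits). Compound 2 gives 9600 nM, and compound 3 gives 45000 nM. Among the two plain numbers compound 3 stands highest; its nearest neighbour is compound 2, with a 4.7-fold higher number from compound 2 to compound 3 (0.67 log units; beyond the scatter). Against the limit of compound 1 the step reads an at least 2.2-fold lower number from compound 1 to compound 3 (0.34 log units; beyond the scatter).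

Compound 4, `COC[C@H](C)[C@@H](C)C(c1ccc(O)c(OC)c1)c1ccc(O)c(OC)c1`, differs from compound 3 by methoxy in place of fluoro on a saturated chain carbon, four bonds along the chain from two aromatic carbons. Among the compounds with values here, the step that bears on this change is an at least 2.2-fold lower number from compound 1 to compound 3 (0.34 log units; beyond the scatter), where a hydroxymethyl became a fluoromethyl at the same end of the chain; no measured pair has a methoxymethyl there. Since the step from compound 1 to compound 3 was at least modest and no larger change is at hand, compound 4 is expected to sit near compound 3, with a step of no change at the digits printed from compound 3 to compound 4 (within the scatter) that need not exceed the scatter. Compound 4 is estimated at 45000 nM, between 15000 nM and 110000 nM.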

Compound 4, half-maximal inhibitory concentration: 68000 nM
Beside the measured number, compound 4's estimate is 1.5-fold (0.18 log units) below it; measured number inside the range.
By their numbers in this assay, from the lowest: compound 2; then compounds 3 and 4 (each within the scatter of the next). At a limit, above all of these: compound 1.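

In this assay the change from fluoro to methoxy, on a saturated chain carbon four bonds along the chain from two aromatic carbons, leaves the two compounds inseparable (a 1.5-fold higher number from compound 3 to compound 4 (0.18 log units; within the scatter)), so the fluoromethyl and methoxymethyl ends cannot be told apart at this place. The 1-isopropylhexyl chain keeps the lower number against the methoxymethyl end as well (a 7.1-fold higher number from compound 2 to compound 4 (0.85 log units; beyond the scatter)), as it did against the fluoromethyl end. The step from the hydroxymethyl end to the methoxymethyl end (an at least 1.4-fold lower number from compound 1 to compound 4 (0.16 log units; that floor lies within the scatter)) cannot be read as a real difference, because it rests on a limit and not on a number: the limit of > 100000 nM in this assay, at which 1 of the 4 values shown sits.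

The compounds shown leave open whether an amine or a carboxylic acid at this end of the chain would move the number. They also leave open whether a longer ether chain here would bring it closer to that of the 1-isopropylhexyl chain.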